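Swapping an Ethyl for a Fluorophenyl on the Sulfonyl

This account rests on a few compounds, and the source may have more. Where it says the series, first, only, none or still open, it means among the compounds named here.

Compound 1 `CS(=O)(=O)N1c2ccccc2CCC1C(=O)Nc1cccc(Cl)c1` gives 60% in a functional assay on HEK293 cells for positive allosteric modulation of metabotropic glutamate receptor 5 (Rattus norvegicus), read by fluorescence and calcium flux; on this read-out higher numbers stand for larger maximal responses and lower numbers for smaller maximal responses. Compound 2 `CCS(=O)(=O)N1c2ccccc2CC[C@H]1C(=O)Nc1cccc(Cl)c1` gives 74% in this assay, the higher of the two measured numbers, with compound 1 sitting lower by more than the usual scatter. Compound 3 `O=C(Nc1cccc(Cl)c1)[C@@H]1CCc2ccccc2N1S(=O)(=O)c1ccccc1F` has not been measured; it differs from compound 2 by 2-fluorophenyl in place of ethyl on a sulfonyl sulfur. Within the data shown here, no pair of measured compounds shows what such a change does here, so only a modest step is expected in this assay, about a number 4 percentage points lower from compound 2 to compound 3 (within the scatter), in no firm direction. Compound 3 is estimated at 70%, within a range from 48% to 92%.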

Compound 3, largest response reached (Emax), in percent of the reference or control that the assay uses: 78%
Estimate against measurement, compound 3: 8 percentage points below; low and high end bracket the measured number.
By their numbers in this assay, from the lowest: compound 1; then compounds 2 and 3 (each within the scatter of the next).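

Putting 2-fluorophenyl in place of ethyl on the sulfonyl sulfur gives a number 4 percentage points higher from compound 2 to compound 3 (within the scatter) in this assay and so shows that this position can carry an aromatic ring as well as a short chain. A group of 7 heavy atoms replaces one of 2, and the maximal response stays within the usual scatter. Nothing available explains why the two groups read alike.

Open, going by these compounds, is whether plain phenyl, without the fluorine, would read the same. Also open, on these data alone, is how an amine or a carboxylic acid on the ring would read.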